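A few compounds are considered here, and "the series" means these few. Any claim that something is new, unique, unknown or untested is made for them only; others in the source may bear on it.

In a functional assay on PC-12 cells (Rattus norvegicus) for cytotoxicity, read by MTT assay, with stated times of 2 h and 24 h, tested at 1 uM (a higher number here means a stronger effect of the compound at the concentration tested, a lower number a weaker effect), compound 1 `Oc1cc(C(F)(F)F)ccc1-c1nc(-c2ccccc2O)n(-c2ccc(Br)cc2)n1` gives 69.4%, compound 2 `COc1ccc(-n2nc(-c3ccc(C(F)(F)F)cc3O)nc2-c2ccccc2O)cc1` gives 69%, and compound 3 `Oc1cc(C(F)(F)F)ccc1-c1nc(-c2ccccc2O)n(-c2ccccc2F)n1` gives 63.4%. On these three numbers compound 3 is not set apart from either of the others: a number 6 percentage points lower from compound 1 to compound 3 (within the scatter), and a number 5.6 percentage points lower from compound 2 to compound 3 (within the scatter). Compound 4 `COc1ccccc1-n1nc(-c2ccc(C(F)(F)F)cc2O)nc1-c1ccccc1O` differs from compound 3 in one place: methoxy in place of fluoro on an aromatic carbon. Among the compounds with values here, no measured step touches this exact place; the closest comparisons are the two exchanges of the aryl on an aromatic nitrogen, both within the scatter, and the exchange of methoxy for bromo on an aromatic carbon, a number 0.4 percentage points lower from compound 1 to compound 2 (within the scatter), also within the scatter. All three steps are flat, so in this assay no step beyond the scatter is expected for compound 4. Compound 4 is estimated at 65%, range 52% to 78%, an expected a number 1.6 percentage points higher from compound 3 to compound 4 (within the scatter).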

Compound 4, a percentage reported as activity, at one concentration (the size of the read-out at that concentration, not a potency): 70.7%
Estimate against measurement, compound 4: 5.7 percentage points below, and the stated range covers the measured number.
By their numbers in this assay, from the lowest: compounds 3, 2, 1 and 4 (each within the scatter of the next).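

In this assay, methoxy in place of fluoro on an aromatic carbon, ortho to a large group, gives a number 7.3 percentage points higher from compound 3 to compound 4 (within the scatter), so this place takes the change without a step beyond the scatter. 2-Methoxyphenyl in place of 4-methoxyphenyl gives a number 1.7 percentage points higher from compound 2 to compound 4 (within the scatter), and 2-methoxyphenyl in place of 4-bromophenyl gives a number 1.3 percentage points higher from compound 1 to compound 4 (within the scatter), so no aryl on the aromatic nitrogen shown here separates from the others. Nothing at hand explains this flat read-out. Going by these compounds, whether an amine or a carboxylic acid at this place would step beyond the scatter remains open.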